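A few compounds are considered here, and "the series" means these few. Any claim that something is new, unique, unknown or untested is made for them only; others in the source may bear on it.

Measured in a functional assay on DLD-1 cells (Homo sapiens) for cytotoxicity, with a stated time of 48 h; on this read-out lower numbers stand for stronger inhibition and higher numbers for weaker inhibition
Compound 1 `Cc1ccc2oc(/C=C/[S+](C)[O-])cc(=O)c2c1` gives 7000 nM
Compound 2 `CCCCOc1ccc2oc(/C=C/[S+](C)[O-])cc(=O)c2c1` gives 4800 nM
Compound 3 `C[S+]([O-])/C=C/c1cc(=O)c2cc(F)ccc2o1` gives 7000 nM

Compound 3 stands level with compound 1, the data showing no change at the digits printed from compound 1 to compound 3 (within the scatter). Its other measured neighbour is separated by a 1.5-fold higher number from compound 2 to compound 3 (0.16 log units; within the scatter), so all three numbers lie within the scatter of one another.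

The next compound, compound 4 `C[S+]([O-])/C=C/c1cc(=O)c2cc(Cl)ccc2o1`, carries chloro in place of fluoro on an aromatic carbon. Among the measured compounds shown here, no measured step involves chloro, so the evidence is indirect. For the measured compounds named here, the steps that bear on it are the exchanges among methyl, butoxy and fluoro on an aromatic carbon. These are the two above and a 1.5-fold lower number from compound 1 to compound 2 (0.16 log units; within the scatter), and none lies beyond the scatter. No step beyond the scatter is therefore expected in this assay.

The expected step is a 1.2-fold lower number from compound 3 to compound 4 (0.07 log units; within the scatter).

Compound 4 is estimated at 6000 nM, with an expected range from 3000 nM to 12000 nM.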

Compound 4, half-maximal inhibitory concentration: 6500 nM
Beside the measured number, compound 4's estimate is 1.1-fold (0.03 log units) below it, and the stated range covers the measured number.
By their numbers in this assay, from the lowest: compounds 2, 4, 1 and 3 (each within the scatter of the next).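

In this assay, chloro is a fourth group at this position on the aromatic carbon, and it too stays inside the scatter against each of the others: the exchange for fluoro gives (a 1.1-fold lower number from compound 3 to compound 4 (0.03 log units; within the scatter)), the exchange for methyl gives (a 1.1-fold lower number from compound 1 to compound 4 (0.03 log units; within the scatter)) and the exchange for butoxy gives (a 1.4-fold higher number from compound 2 to compound 4 (0.13 log units; within the scatter)). Compounds 1, 2, 3 and 4 therefore form a single group with no order among them, and the change from fluoro to chloro adds no step beyond the scatter to those already seen. No measurement shown here offers an account of this result.

The compounds shown leave open whether a group of another kind at this position, such as an amine or a carboxylic acid, would give a step beyond the scatter. On these data alone, all four vary at this one position alone, and the effect of a change elsewhere on the shared core remains open.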